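The source may report more compounds than this note shows. Statements on the series, on what has been measured and on what is new or still open speak of the compounds shown alone.

Compounds measured so far:
compound 1 `COc1ccc(/C=C/C2(C)C=CC(=O)O2)c(OC)c1`: 53600 nM
compound 2 `COc1cc(OC)c(/C=C/C2(C)C=CC(=O)O2)c(OC)c1`: 458000 nM

Both values come from a functional assay on HaCaT cells (Homo sapiens) for inhibition, read by sulforhodamine B assay, with a stated time of 48 h; on this read-out higher numbers stand for weaker inhibition of growth and lower numbers for stronger inhibition of growth. For the measured compounds named here, of these two numbers, compound 1 holds the lower, and compound 2 is its only neighbour. The next compound, compound 3 `COc1ccc(/C=C/C2(C)C=CC(=O)O2)cc1`, has not yet been measured in this assay. It differs from compound 1 by hydrogen in place of methoxy on an aromatic carbon. Going by the values given here, only one measured step bears on this change, the reverse kind of exchange, where a methoxy enters: an 8.5-fold higher number from compound 1 to compound 2 (0.93 log units; beyond the scatter). That step is modest, and it involves a different aromatic carbon, so it guides the direction more than the size. A smaller move towards a lower number is therefore expected, and it may not clear the scatter by much. The expected step is a 1.8-fold lower number from compound 1 to compound 3 (0.25 log units; within the scatter). For compound 3 the estimated value is 30000 nM, with an expected range from 8000 nM to 120000 nM.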

Compound 3, concentration for total growth inhibition: 316000 nM
The estimate for compound 3 lay 11-fold (1.02 log units) below the measured number; the measured number lies above the stated range.
By their numbers in this assay, from the lowest: compound 1; then compounds 3 and 2 (each within the scatter of the next).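

In this assay the methoxy on the aromatic carbon ortho to a group of 9 heavy atoms proves favourable: replacing it with hydrogen gives a 5.9-fold higher number from compound 1 to compound 3 (0.77 log units; beyond the scatter) and so weakens growth inhibition. The earlier step of an 8.5-fold higher number from compound 1 to compound 2 (0.93 log units; beyond the scatter) concerned a methoxy entering at a different aromatic carbon, so the two steps together show that the outcome of a methoxy exchange depends on the carbon involved, and that compound 1 gains from its methoxy at this one. Nothing available explains why this position behaves this way.

The compounds shown leave open whether the gain is specific to methoxy or would also be seen with a hydroxyl, a fluorine or an ethoxy on this carbon. They also leave open whether the same step would hold with the other methoxy of compound 1 changed.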